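A few compounds are considered here, and "the series" means these few. Any claim that something is new, unique, unknown or untested is made for them only; others in the source may bear on it.

Measured so far:
compound 1, `Cc1cccc(N2CCC(C(=O)Nc3ccc4c(c3)NC(=O)CO4)CC2)c1`, 490 nM
compound 2, `CCOC(=O)C1(C)Oc2ccc(NC(=O)C3CCN(c4cc(F)c(F)c(F)c4)CC3)cc2NC1=O`, 870 nM
compound 3, `O=C(Nc1cccc2[nH]ccc12)C1CCN(c2cccc(C(F)(F)F)c2)CC1`, 230 nM

These three compounds were tested in a functional assay for antagonist activity at transient receptor potential cation channel subfamily V member 1 (Homo sapiens), read by FLIPR and calcium flux; a lower number here means a stronger inhibitor, a higher number a weaker inhibitor. Compound 1 has the second highest of the three numbers. Its nearest neighbour is compound 2, whose value lies within the usual scatter, so nothing separates the two. Compound 3 sits furthest away, with a lower number that lies beyond the scatter.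

Compound 4, `O=C1COc2ccc(NC(=O)C3CCN(c4cccc(Br)c4)CC3)cc2N1`, has not been measured yet. It differs from compound 1 in one place: bromo in place of methyl on an aromatic carbon. Among the compounds with values here, no measured pair here shows this exact swap, so the step is expected to be small, with no change beyond the scatter: a 1.2-fold lower number from compound 1 to compound 4 (0.09 log units; within the scatter). Compound 4 is therefore estimated at 400 nM, in a range from 150 nM to 1200 nM.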

Compound 4, half-maximal inhibitory concentration: 330 nM
Estimate against measurement, compound 4: 1.2-fold (0.08 log units) above; the range from low to high includes it.
By their numbers in this assay, from the lowest: compounds 3, 4, 1 and 2 (each within the scatter of the next, the first and the last beyond it).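

Within the data shown here, replacing 3-methylphenyl with 3-bromophenyl on the shared core in this assay gives the first step that can be read at this position (a 1.5-fold lower number from compound 1 to compound 4 (0.17 log units; within the scatter)). At this place on the aromatic ring, then, bromo and methyl cannot be told apart, and swapping one for the other costs no measurable activity. No measurement here bears on why the two groups match.

The compounds shown leave open whether a larger or differently built group, such as an amine, a carboxylic acid or a methoxy group, would fare the same at this place. Going by these compounds, whether the same swap gives a similar result on a different core also remains open.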